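The source may hold more compounds than are shown below. What is called first, only, known or untested is meant among the compounds shown, and "the series" means these compounds.

Of the compounds shown here, three have so far been measured in a functional assay on CHO cells with metabotropic glutamate receptor 2 (Homo sapiens) as the target, read by GTPgammaS binding (a lower number here means a smaller maximal response, a higher number a larger maximal response), and the numbers differ widely. Compound 1 `Cc1cc(C)nc(N2CCN(c3ccn4c(CC(F)(F)F)cnc4c3C#N)CC2)n1` gives 128%. Compound 2 `CCCc1cnc2c(C#N)c(N3CCN(c4ncccn4)CC3)ccn12` gives 248%. Compound 3 `CC(C)(C)c1ccc(-c2ccn3c(CC(F)(F)F)cnc3c2C#N)cc1` gives 272%. Compound 3 therefore stands highest of the three: its nearest neighbour is compound 2, whose value lies a moderate distance below it and beyond the usual scatter, while compound 1 lies far below it, also well beyond the scatter.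

Compound 4 `N#Cc1c(-c2ccc(N3CCCCC3)cc2)ccn2c(CC(F)(F)F)cnc12` has not yet been measured. It keeps the shared core and the trifluoroethyl and nitrile groups of compound 3, and differs from compound 3 in one place: piperidin-1-yl in place of tert-butyl on an aromatic carbon. Among the compounds with values here, no pair of measured compounds differs by a change of this kind, so there is no measured step that can be carried over directly. Within the data shown here, what is known is only that compound 3 sits at the top of the range observed.

Among the measured compounds shown here, with no close precedent, the expected step in this assay is a small one, most likely within the scatter, with a lean toward a somewhat lower maximal response. Compound 4 is expected to give about 250%, within an estimated range from 180% to 320%. This estimate means an expected step of a number 22 percentage points lower from compound 3 to compound 4 (beyond the scatter) in this assay.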

Compound 4, largest response reached (Emax), in percent of the reference or control that the assay uses: 123%
For compound 4 the middle estimate is 127 percentage points above the measured one; measured number outside the range, below it.
By their numbers in this assay, from the lowest: compounds 4 and 1 (each within the scatter of the next); then compound 2; then compound 3.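

In this assay, putting piperidin-1-yl in place of tert-butyl on this aromatic carbon, para to a large group, brings a number 149 percentage points lower from compound 3 to compound 4 (beyond the scatter), a large step. Within the data shown here, this is the first change in one place among the measured compounds, and it shows that the maximal response can depend strongly on the group at this position, even though both groups carry no net charge and neither has a hydrogen-bond donor. The entering group differs from the one leaving in several ways at once, with more heavy atoms, a six-membered non-aromatic ring and a nitrogen that counts as a hydrogen-bond acceptor, and nothing measured here explains the drop.

On these data alone, whether the fall goes with the ring or with the nitrogen remains open: a cyclohexyl group at this place would keep a six-membered ring without the nitrogen, while a dimethylamino group would keep a nitrogen without the ring. As far as these compounds go, it is also open whether the same change would give a step of similar size with a propyl group in place of the trifluoroethyl group elsewhere on the shared core.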